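The source may hold more compounds than are shown below. What is called first, only, known or untested is meant among the compounds shown, and "the series" means these compounds.

Measured compounds:
compound 1 `Cn1nc2c(=O)n(CC3(O)CCN(Cc4ccc(-c5ccco5)cc4Cl)CC3)cnc2c1-c1ccc(CO)cc1`; in an assay on isolated protein for inhibition of ubiquitin carboxyl-terminal hydrolase 7 (Homo sapiens), with stated times of 30 min and 2 h (on this read-out higher numbers stand for weaker inhibition and lower numbers for stronger inhibition), compound 1 gives 42.5 nM
compound 2 `Cn1nc2c(=O)n(CC3(O)CCN(Cc4ccc(-c5ccco5)cc4Cl)CC3)cnc2c1-c1ccc(C2(N)CC2)cc1`; compound 2 gives 66.1 nM
compound 3 `Cn1nc2c(=O)n(CC3(O)CCN(Cc4ccc(C5=CCCC5)cc4Cl)CC3)cnc2c1-c1ccc(CN)cc1`; compound 3 gives 76.9 nM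

Compound 3 stands at the highest of the three numbers, but its gaps to compound 2 and to compound 1 are both within the scatter, so no order among them can be claimed. Compound 4 `Cn1nc2c(=O)n(CC3(O)CCN(Cc4ccc(C5CCCO5)cc4Cl)CC3)cnc2c1-c1ccc(CN)cc1` differs from compound 3 in one place: oxolan-2-yl in place of cyclopent-1-en-1-yl on an aromatic carbon. For the measured compounds named here, the only measured step, a 1.6-fold higher number from compound 1 to compound 2 (0.19 log units; within the scatter), changes a different part of the molecule and does not bear on this exchange. Compound 1 and compound 3 differ in two places, and their values lie within the scatter of each other. Going by the values given here, with no step at this position to draw on, no change beyond the scatter is expected; the step of a 1.0-fold lower number from compound 3 to compound 4 (0.01 log units; within the scatter) is the expected outcome. Compound 4 is therefore estimated at 75 nM, between 35 nM and 160 nM.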

Compound 4, half-maximal inhibitory concentration: 3820 nM
The estimate for compound 4 lay 51-fold (1.71 log units) below the measured number; the whole stated range lies below it.
By their numbers in this assay, from the lowest: compounds 1, 2 and 3 (each within the scatter of the next); then compound 4.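

In this assay, oxolan-2-yl in place of cyclopent-1-en-1-yl gives a 50-fold higher number from compound 3 to compound 4 (1.70 log units; beyond the scatter), the first step beyond the scatter among these compounds. The position para to the large group is therefore sensitive to this exchange, even though both groups have 5 heavy atoms and a five-membered non-aromatic ring. No measurement is available that explains this change. The exchange adds a ring oxygen and removes a double bond together, so the compounds shown leave open which of the two matters. A plain cyclopentyl group would separate them, and a pyrrolidin-2-yl group would show how a ring amine compares with that oxygen.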